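The compounds below may be only part of what the source reports. "The series", "measured", "known", "first", "only" and "open" are said of these compounds alone.

Working notes on the series. Compound 1, `CCN(c1nc(C)nc2c1nnn2-c1ccc(C(C)C)cc1Br)C(COC)COC`, has been measured in an in vitro assay on 293-EBNA cells for binding affinity to corticotropin-releasing factor receptor 1 (Homo sapiens) (on this read-out higher numbers stand for weaker inhibition and lower numbers for stronger inhibition), where compound 1 gives 123 nM. Compound 2, `CCCCN(CC)c1nc(C)nc2c1nnn2-c1ccc(S(C)(=O)=O)cc1Br`, gives 100 nM in this assay. The gap between these two values lies within the scatter of repeated measurements, so the two compounds are not separated by this read-out. Within the data shown here, the two measured compounds differ in more than one place, so no single step between measured compounds is available.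

Compound 3, `CCC(COC)Oc1nc(C)nc2c1nnn2-c1ccc(C(C)C)cc1Br`, is not yet measured in this assay. It differs from compound 1 at one place on the shared core: a group of 7 heavy atoms (5 carbon, 2 oxygen; no ring) in place of a group of 10 heavy atoms (7 carbon, 1 nitrogen, 2 oxygen; no ring), on an aromatic carbon. The group that leaves is the larger one and carries a nitrogen; the group that enters is 1-(methoxymethyl)propoxy.

Among the measured compounds shown here, no measured pair shows a change of this kind, so the expectation rests on compound 1 alone, starting from compound 1 at 123 nM. A moderate move toward a higher number is expected, the estimated step from compound 1 to compound 3 being a 2.0-fold higher number from compound 1 to compound 3 (0.31 log units; beyond the scatter), but a step no larger than the scatter cannot be excluded. Compound 3 is accordingly estimated at 250 nM in this assay, within a range from 70 nM to 900 nM.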

Compound 3, inhibition constant: 1.9 nM
Beside the measured number, compound 3's estimate is 130-fold (2.12 log units) above it, outside the stated range (below it).
By their numbers in this assay, from the lowest: compound 3; then compounds 2 and 1 (each within the scatter of the next).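

In this assay, putting 1-(methoxymethyl)propoxy in place of the larger nitrogen-bearing group gives a 65-fold lower number from compound 1 to compound 3 (1.81 log units; beyond the scatter), so this position, on an aromatic carbon next to the ring nitrogen, responds strongly to a single change, far beyond the scatter. The earlier two compounds differed in more than one place and could not show this; the step now isolates this position and shows that the group held there can by itself set the read-out, with the smaller, nitrogen-free group giving the lower number in this one pair. No supporting measurement bears on why the step is so large.

Going by these compounds, the step exchanges the attached nitrogen for an oxygen and alters the chain at the same time, so the shares of the two changes remain open; a secondary amine carrying the same 1-(methoxymethyl)propyl chain would separate them. Also open, on these data alone, is how much of the chain itself matters, which a plain ethoxy at this position would address, and whether the step holds with other groups elsewhere on the shared core.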